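Small Clearance Numbers and a New Unsaturated Acid

The source may hold more compounds than are shown below. What is called first, only, known or untested is meant among the compounds shown, and "the series" means these compounds.

In an ADME assay on the whole organism (strain CD-1) for pharmacokinetics, with Mus musculus as the target, at a dose of 3 mg/kg by the intravenous route (on this read-out lower numbers stand for slow clearance and higher numbers for fast clearance), compound 1 `C[C@H](CCCOc1ccccc1CN(C)C(=O)c1ccc(-c2ccco2)cc1)CC(=O)O` gives 0.3 mL/min/kg, while compound 2 `C[C@@H](CCCOc1ccccc1CN(C)C(=O)c1ccc(-c2ccco2)cc1)CC(=O)O` gives 1.3 mL/min/kg, the higher of the two numbers. Compound 3 `CN(Cc1ccccc1OCCC/C=C/C(=O)O)C(=O)c1ccc(-c2ccco2)cc1` differs from compound 2 as follows: 2-carboxyethenyl in place of 1-(carboxymethyl)ethyl on a saturated chain carbon, three bonds along the chain from an oxygen on an aromatic ring. It has 2-carboxyethenyl in place of 1-(carboxymethyl)ethyl. Among the measured compounds shown here, the only measured step, a 4.3-fold higher number from compound 1 to compound 2 (0.64 log units; beyond the scatter), is a modest one that reflects configuration alone (the fact that compounds 1 and 2 differ only in the configuration as drawn), and it does not test this change. A shift beyond the scatter is therefore not expected, and the estimated step is a 1.2-fold higher number from compound 2 to compound 3 (0.06 log units; within the scatter). For compound 3, the expected clearance is 1.5 mL/min/kg, with an estimated range of 0.4 mL/min/kg to 5.5 mL/min/kg.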

Compound 3, clearance: 67 mL/min/kg
Compound 3: the middle estimate sits 45-fold (1.65 log units) below what was measured, and the stated range ends below it.
By their numbers in this assay, from the lowest: compound 1; then compound 2; then compound 3.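

At this position on the chain, the swap of 1-(carboxymethyl)ethyl for 2-carboxyethenyl is far from neutral in this assay: it brings a 52-fold higher number from compound 2 to compound 3 (1.71 log units; beyond the scatter) and a 220-fold higher number from compound 1 to compound 3 (2.35 log units; beyond the scatter). Both steps are much larger than the one difference seen before, which came from configuration alone. Nothing in the data shown explains why clearance climbs so steeply.

The change adds a double bond and removes the branch together, so the compounds shown cannot say which of the two matters. An unbranched, fully saturated chain ending in the carboxylic acid would pull these two features apart.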